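A few compounds are considered here, and "the series" means these few. Any claim that something is new, unique, unknown or untested is made for them only; others in the source may bear on it.

Compound 1 `CC(C)OC(=O)N1CCC2(CC1)CC(CCCOc1ccc(S(C)(=O)=O)c(F)c1)C2`: 18 nM
Compound 2 `CS(=O)(=O)c1ccc(OCCCC2CC3(CCN(C(=O)OC4CCCC4)CC3)C2)cc1F`: 23 nM

Among the measured compounds shown here, in a functional assay on cells for agonist activity at Glucose-dependent insulinotropic receptor (Homo sapiens), read by HTRF and cAMP accumulation, with a stated time of 30 min (on this read-out lower numbers stand for an effect already at smaller amounts and higher numbers for an effect only at larger amounts of compound), compound 2 gives 23 nM, a value that lies within the scatter of compound 1; the only measured step on this position is a 1.3-fold higher number from compound 1 to compound 2 (0.11 log units; within the scatter). Compound 3 `CC(C)(C)COC(=O)N1CCC2(CC1)CC(CCCOc1ccc(S(C)(=O)=O)c(F)c1)C2` carries neopentyl in place of cyclopentyl on an oxygen next to a carbonyl group. For the measured compounds named here, the one step that bears on this change, a 1.3-fold higher number from compound 1 to compound 2 (0.11 log units; within the scatter), exchanged two alkyl groups on the same oxygen without an effect beyond the scatter, so a comparable outcome is expected here. The expected step is a 1.1-fold higher number from compound 2 to compound 3 (0.04 log units; within the scatter), none beyond the scatter. Compound 3 is therefore estimated at 25 nM, with a range from 10 nM to 60 nM.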

Compound 3, half-maximal effective concentration: 31 nM
The estimate for compound 3 lay 1.2-fold (0.09 log units) below the measured number; the measured number falls inside the stated range.
By their numbers in this assay, from the lowest: compounds 1, 2 and 3 (each within the scatter of the next).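

In this assay the open-chain neopentyl stands on this oxygen in place of the cyclopentyl ring with no effect beyond the scatter: a 1.3-fold higher number from compound 2 to compound 3 (0.13 log units; within the scatter). Measured against isopropyl, the widest step in the set also stays within the scatter, a 1.7-fold higher number from compound 1 to compound 3 (0.24 log units; within the scatter), so isopropyl, cyclopentyl and neopentyl on this oxygen cannot be told apart in this read-out. No supporting data bear on these steps.

Open, going by these compounds, is whether this position accepts anything other than a plain alkyl group, such as a phenyl ring, or a chain ending in an amine or a carboxylic acid.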